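The compounds below may be only part of what the source reports. "The series", "measured", "known", "first", "only" and "open" are said of these compounds alone.

Measured so far:
compound 1 `O=C1Nc2ccccc2/C1=C\C(=O)c1cc(F)cc(F)c1` gives 15700 nM
compound 2 `CCC(=O)Nc1cccc(C(=O)/C=C2/C(=O)Nc3ccccc32)c1` gives 7500 nM
compound 3 `O=C1Nc2ccccc2/C1=C\C(=O)c1ccccc1F` gives 11800 nM

All three numbers come from a functional assay on BGC-823 cells (Homo sapiens) for inhibition, read by MTT assay, with a stated time of 72 h (on this read-out higher numbers stand for weaker inhibition and lower numbers for stronger inhibition), and the compounds share a core. Compound 2 (7500 nM) lies within the scatter of compound 3 (11800 nM). Only compound 1 (15700 nM) stands beyond the scatter from compound 2, with a higher number.

Compound 4 `CC(=O)Nc1cccc(C(=O)/C=C2/C(=O)Nc3ccccc32)c1` is compound 2 with one change (hydrogen in place of methyl on a saturated chain carbon bound to a carbonyl carbon): hydrogen in place of methyl on a saturated chain carbon bound to a carbonyl carbon, which turns propanoylamino into acetamido. Within the data shown here, no measured pair shows this change, so the data offer no direct guide to its size. In this assay no step beyond the scatter is expected, a judgement resting only on compound 2 (7500 nM) as the closest measured structure and on the small count of atoms that change. The expected step (a 1.1-fold higher number from compound 2 to compound 4 (0.05 log units; within the scatter)) stays within the scatter. The estimated value for compound 4 is 8500 nM (expected range 3500 nM to 20000 nM).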

Compound 4, half-maximal inhibitory concentration: 9100 nM
Compound 4: the middle estimate sits 1.1-fold (0.03 log units) below what was measured, within the range that was stated.
By their numbers in this assay, from the lowest: compounds 2, 4, 3 and 1 (each within the scatter of the next, the first and the last beyond it).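

In this assay, among these compounds, the only measured pair at this position gives a 1.2-fold higher number from compound 2 to compound 4 (0.08 log units; within the scatter), so the change from propanoylamino to acetamido stays within the scatter. The earlier compounds shown here formed no such pair; this one shows that replacing methyl with hydrogen on the saturated chain carbon bound to a carbonyl carbon, shortening ethyl to methyl, leaves no readable difference in this cellular read-out. No measurement at hand accounts for this outcome.

Still open, going by these compounds, is whether the number stays within the scatter with a longer chain, such as butanoylamino, or with an amine or a carboxylic acid at the end of the chain. Among the compounds shown here, this single pair covers only one small step and does not show how far the chain can be altered before the number moves beyond the scatter.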